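Adding a hydroxy to compound 2

A few compounds are considered here, and "the series" means these few. Any claim that something is new, unique, unknown or untested is made for them only; others in the source may bear on it.

Going by the values given here, in a functional assay on A549 cells (Homo sapiens) for cytotoxicity, read by colorimetric assay and MTT assay, with a stated time of 72 h (on this read-out lower numbers stand for stronger inhibition and higher numbers for weaker inhibition), compound 2 (`O=C1C=CC(O)(c2cc(=O)c3ccccc3o2)C=C1`) gives 5240 nM, the lowest of the numbers so far. Compound 1 (`COCOc1cc(O)c2c(=O)cc(C3(O)C=CC(=O)C=C3)oc2c1`) gives 24600 nM. Compound 3 (`COC1(c2cc(=O)c3ccccc3o2)C=CC(=O)C=C1`) reads > 74600 nM, which is a limit of the assay and not a number. Compound 4 (`O=C1C=CC(O)(c2cc(=O)c3c(O)cccc3o2)C=C1`) differs from compound 2 by hydroxy in place of hydrogen on an aromatic carbon. Among the compounds with values here, the only measured step, an at least 14-fold higher number from compound 2 to compound 3 (1.15 log units; beyond the scatter), is large, but it concerns an oxygen on a saturated carbon, so it offers little guidance here. Compound 1 also carries a hydroxy on an aromatic carbon, but it differs elsewhere too, so its 24600 nM cannot isolate this change. The expected step, a 1.3-fold lower number from compound 2 to compound 4 (0.12 log units; within the scatter), is therefore estimated to stay within the scatter. For compound 4, the estimated value is 4000 nM, with an expected range of 1000 nM to 16000 nM.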

Compound 4, half-maximal inhibitory concentration: 5070 nM
Estimate against measurement, compound 4: 1.3-fold (0.10 log units) below; low and high end bracket the measured number.
By their numbers in this assay, from the lowest: compounds 4 and 2 (each within the scatter of the next); then compound 1. At a limit, above all of these: compound 3.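

In this assay, the new hydroxy on the aromatic carbon, ortho to a fused ring, leaves no readable difference, with a 1.0-fold lower number from compound 2 to compound 4 (0.01 log units; within the scatter). A methoxymethoxy on an aromatic carbon does register, since hydrogen in its place gives a 4.9-fold lower number from compound 1 to compound 4 (0.69 log units; beyond the scatter). Nothing measured here accounts for either outcome.

One hydroxy cannot show whether this aromatic carbon accepts any group equally well. An amine or a carboxylic acid in the same place could still read differently, so the flat result holds only for hydroxy.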